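Clearance notes: aryl-ethoxy tail replaced by a dimethylthiazole

A few compounds are considered here, and "the series" means these few. Any claim that something is new, unique, unknown or untested is made for them only; others in the source may bear on it.

Measured so far in an ADME assay on the whole organism (Rattus norvegicus, strain Sprague-Dawley) for pharmacokinetics, read by LC-MS, at a dose of 1 mg/kg by the intravenous route; on this read-out lower numbers stand for slow clearance and higher numbers for fast clearance:
compound 1 `COc1ccc(CCOc2ccc(-c3c(C)nc(C)c([C@H](OC(C)(C)C)C(=O)O)c3N3CCC(C)(C)CC3)cc2)cc1` — 13.4 mL/min/kg
compound 2 `Cc1nc(C)c([C@H](OC(C)(C)C)C(=O)O)c(N2CCC(C)(C)CC2)c1-c1ccc(OCCc2ccc(F)c(F)c2)cc1` — 5.8 mL/min/kg

Compound 2 holds the lowest of the two numbers; its nearest neighbour is compound 1, which differs only in the tail group and gave a 2.3-fold lower number from compound 1 to compound 2 (0.36 log units; beyond the scatter). That single step is the whole of what is known about the tail in this assay.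

Compound 3 `Cc1nc(C)c(CCOc2ccc(-c3c(C)nc(C)c([C@H](OC(C)(C)C)C(=O)O)c3N3CCC(C)(C)CC3)cc2)s1` is not yet measured. It differs from compound 2 by 2,4-dimethyl-1,3-thiazol-5-yl in place of 3,4-difluorophenyl on a saturated chain carbon, two bonds along the chain from an oxygen on an aromatic ring. Among the measured compounds shown here, no measured pair covers an exchange of this kind: the one step in hand swaps one six-membered carbon ring for another, whereas here a five-membered ring with two hetero atoms enters. The step from compound 1 to compound 2 was modest and beyond the scatter, so a change of the tail can move this assay, but its direction for compound 3 cannot be read from the data.

For compound 3 the estimate in this assay is 9 mL/min/kg, with a range of 4 mL/min/kg to 22 mL/min/kg; this expected step of a 1.6-fold higher number from compound 2 to compound 3 (0.19 log units; within the scatter) from compound 2 is placed close to the scatter, wide to either side.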

Compound 3, clearance: 30.1 mL/min/kg
The estimate for compound 3 lay 3.3-fold (0.52 log units) below the measured number; measured number above the stated range.
By their numbers in this assay, from the lowest: compound 2; then compound 1; then compound 3.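

In this assay, the position on a saturated chain carbon, two bonds along the chain from an oxygen on an aromatic ring, can now be seen to move the number upward as well as downward. The 2,4-dimethyl-1,3-thiazol-5-yl group gives a 5.2-fold higher number from compound 2 to compound 3 (0.72 log units; beyond the scatter) when it replaces 3,4-difluorophenyl and a 2.2-fold higher number from compound 1 to compound 3 (0.35 log units; beyond the scatter) when it replaces 4-methoxyphenyl, so both aryl tails sit beyond the scatter below it, whereas the earlier exchange of one six-membered carbon ring for another showed only a 2.3-fold lower number from compound 1 to compound 2 (0.36 log units; beyond the scatter). Nothing among the data speaks to why the five-membered ring stands highest of the three tails.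

On these data alone, whether the rise follows the thiazole ring itself or its two methyl groups stays open, as does the standing at this position of an unsubstituted 1,3-thiazol-5-yl or a pyridin-3-yl ring. Also open, as far as these compounds go, is whether the same order of tails would hold with a methoxy group in place of the tert-butoxy group on the shared core.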